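Methyl for fluoro on the pyridinyl ring: exposure estimate

The source may report more compounds than this note shows. Statements on the series, on what has been measured and on what is new or still open speak of the compounds shown alone.

Measured compounds:
- compound 1, `Cn1c(COc2cccc(C(=O)O)c2)nc2ccc(Oc3ccc(Cl)cn3)cc21`: 1010 ng.h/mL
- compound 2, `Cn1c(COc2cccc(C(=O)O)c2)nc2ccc(Oc3ncc(Cl)cc3Cl)cc21`: 1400 ng.h/mL
- compound 3, `Cn1c(COc2cccc(C(=O)O)c2)nc2ccc(Oc3ncc(Cl)cc3F)cc21`: 3910 ng.h/mL

In an ADME assay on the whole organism (strain Zucker) for pharmacokinetics, with Rattus norvegicus as the target, with stated times of 24 h and 14 days, at a dose of 3 mg/kg by the oral route (on this read-out lower numbers stand for lower exposure and higher numbers for higher exposure at the dose given), compound 3 stands highest of the three, and both gaps below it are beyond the scatter: a 2.8-fold higher number from compound 2 to compound 3 (0.45 log units; beyond the scatter) and a 3.9-fold higher number from compound 1 to compound 3 (0.59 log units; beyond the scatter). The step from compound 1 to compound 2, a 1.4-fold higher number from compound 1 to compound 2 (0.14 log units; within the scatter), stays within the scatter.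

Compound 4, `Cc1cc(Cl)cnc1Oc1ccc2nc(COc3cccc(C(=O)O)c3)n(C)c2c1`, differs from compound 3 by methyl in place of fluoro on an aromatic carbon, turning the (5-chloro-3-fluoropyridin-2-yl)oxy group into a (5-chloro-3-methylpyridin-2-yl)oxy group. Among the compounds with values here, no measured step puts a methyl at this position, so the estimate rests only on what the same position shows with hydrogen, chloro and fluoro: fluoro sits highest, chloro and hydrogen lie modestly lower and within the scatter of each other. Methyl is a third kind of group here, so compound 4 is expected to fall below compound 3 but above compounds 1 and 2, an estimated step of a 2.0-fold lower number from compound 3 to compound 4 (0.29 log units; within the scatter). Compound 4 is thus estimated at 2000 ng.h/mL, with a range from 800 ng.h/mL to 5000 ng.h/mL.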

Compound 4, area under the concentration-time curve: 1250 ng.h/mL
The estimate for compound 4 lay 1.6-fold (0.20 log units) above the measured number, and the stated range covers the measured number.
By their numbers in this assay, from the lowest: compounds 1, 4 and 2 (each within the scatter of the next); then compound 3.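

In this assay, methyl at this position does not keep the high exposure seen with fluoro: a 3.1-fold lower number from compound 3 to compound 4 (0.50 log units; beyond the scatter). Methyl also does not separate from the other two groups tested on this aromatic carbon, with a 1.1-fold lower number from compound 2 to compound 4 (0.05 log units; within the scatter) and a 1.2-fold higher number from compound 1 to compound 4 (0.09 log units; within the scatter), so among hydrogen, chloro, methyl and fluoro, only fluoro stands apart. The material shown offers nothing that explains this difference.

The compounds shown leave open how a methoxy group, an amine or a nitrile would read on this carbon, and so whether fluoro is unique here. They also leave open whether fluoro would still stand apart if a trifluoromethyl group replaced the chloro group, which stays the same in all four compounds.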